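The source may hold more compounds than are shown below. What is called first, only, known or untested is meant among the compounds shown, and "the series" means these compounds.

Measured so far:
compound 1 `CCCCCCCCS(=O)(=O)Nc1cc(-c2ccc(O)cc2)ccc1C(=O)O`, 64800 nM
compound 2 `CCCCCCCCS(=O)(=O)Nc1ccc(-c2ccccc2OC)cc1C(=O)O`, 27600 nM
compound 3 `CCCCCCCCS(=O)(=O)Nc1ccc(C(=O)c2ccc(CCCC)cc2)cc1C(=O)O`, 31700 nM

All three numbers come from an assay on mitochondria (strain BALB/c) for inhibition of glycerol-3-phosphate acyltransferase 1, mitochondrial (Mus musculus), read by scintillation counting, with a stated time of 10 min; a lower number here means a stronger inhibitor, a higher number a weaker inhibitor. Compound 2 gives the lowest of the three; compound 3 sits within the scatter of compound 2, while compound 1 lies beyond it with a higher number. Among the measured compounds shown here, no step between two measured compounds differing in one place is available, so the size of any change can only be judged from the spread seen.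

Compound 4 `CCCCCCCCS(=O)(=O)Nc1ccc(/C=C/c2ccc(OC)cc2)cc1C(=O)O` differs from compound 2 in one place: 2-(4-methoxyphenyl)ethenyl in place of 2-methoxyphenyl on an aromatic carbon. Compound 3, which also carries a longer group, gives 31700 nM, close to compound 2. The expectation in this assay is therefore no step beyond the scatter, with a slight lean toward a lower number. Compound 4 is expected near 22000 nM, range 8000 nM to 60000 nM, which would be an expected step of a 1.3-fold lower number from compound 2 to compound 4 (0.10 log units; within the scatter).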

Compound 4, half-maximal inhibitory concentration: 37100 nM
Estimate against measurement, compound 4: 1.7-fold (0.23 log units) below, and the stated range covers the measured number.
By their numbers in this assay, from the lowest: compounds 2, 3, 4 and 1 (each within the scatter of the next, the first and the last beyond it).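

In this assay, 2-(4-methoxyphenyl)ethenyl in place of 2-methoxyphenyl gives a 1.3-fold higher number from compound 2 to compound 4 (0.13 log units; within the scatter). Among the compounds shown here, this is the first one-place step: on this aromatic carbon, meta to a carboxy group and para to a large group, the larger group with its double bond leaves the number within the scatter. No measurement on these groups is available to explain the result.

From the compounds shown here alone, whether an amine or a carboxylic acid on this carbon would move the number beyond the scatter remains open. Also open, going by these compounds, is how a hydroxy group in place of the methoxy group would read with the ethenyl link kept.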